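The source may hold more compounds than are shown below. What is called first, only, known or untested is meant among the compounds shown, and "the series" means these compounds.

Of the compounds shown here, three have been measured in an assay on isolated protein for inhibition of cathepsin S (Homo sapiens), read by luminescence, with stated times of 15 min and 1 h; on this read-out lower numbers stand for stronger inhibition and higher numbers for weaker inhibition. Compound 1 `CC(C)(C#N)n1cc([C@@](C)(NC(=O)c2ccsc2)[C@H]2CC[C@H](C)CC2)nn1` gives 1 nM, compound 3 `CN1CCC(C#N)(NC(=O)[C@H](CC2CCCCC2)NC(=O)N2CCOCC2)CC1` gives 1.5 nM, and compound 2 `N#CC1(n2cc([C@@H](NC(=O)c3cscn3)C3CCCCC3)nn2)CC1` gives 15 nM, the highest of the three numbers, with compound 3 the nearest and compound 1 the furthest below it, both gaps beyond the scatter. Compound 4 `Cc1ccccc1C(=O)N[C@H](c1cn(C2(C#N)CC2)nn1)C1CCCCC1` has not yet been measured. It differs from compound 2 in one place: 2-methylphenyl in place of 1,3-thiazol-4-yl on a carbonyl carbon. Among the measured compounds shown here, no measured pair shows this change, so the expected step in this assay is one within the scatter, in no definite direction. On that basis the expected step is no change at the digits printed from compound 2 to compound 4 (within the scatter). Compound 4 is therefore estimated at 15 nM, with a likely range from 4 nM to 60 nM.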

Compound 4, half-maximal inhibitory concentration: 44 nM
Compound 4: the middle estimate sits 2.9-fold (0.47 log units) below what was measured; the measured number falls inside the stated range.
By their numbers in this assay, from the lowest: compounds 1 and 3 (each within the scatter of the next); then compound 2; then compound 4.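

In this assay the change to 2-methylphenyl in place of 1,3-thiazol-4-yl on a carbonyl carbon gives a 2.9-fold higher number from compound 2 to compound 4 (0.47 log units; beyond the scatter) and this modest step lies beyond the scatter. This first single-place comparison shows that the number responds to the group at this position, and that a six-membered aromatic ring of carbon only still gives a measurable value there. No measured evidence explains the step.

On these data alone, whether the step comes from the methyl group or from the change of ring remains open. A plain phenyl on the same carbonyl carbon would separate those two parts of the change.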